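Cytotoxicity of a Glycosylated Oxadiazole Pair on Macrophages

The compounds below may be only part of what the source reports. "The series", "measured", "known", "first", "only" and "open" are said of these compounds alone.

The account concerns three measured compounds and one still to be measured, all read in an ADME assay on RAW264.7 cells (Mus musculus) for cytotoxicity, read by MTT assay, with a stated time of 48 h; a higher number here means that more compound is tolerated, a lower number that less compound is tolerated. Compound 1 `C#CCOc1ccc(-c2noc(NC3CCCCC3)n2)cc1` gives 38.3 ug/mL. Compound 2 `CC(=O)OC[C@H]1O[C@H](OC[C@@H](Cn2cc(CN(c3nc(-c4cccc(C)c4)no3)C3CCCCC3)nn2)OC(C)=O)C=C[C@@H]1OC(C)=O` gives 46.4 ug/mL, the highest of the three numbers, although its separation from compound 1 lies within the scatter, so no order between those two is claimed. Compound 3 `C#CCN(c1nc(-c2ccc(Br)cc2)no1)C1CCCCC1` gives 15.7 ug/mL, a number that stands beyond the scatter below compound 2. Compound 3 differs from compound 2 in several places at once, so nothing about any single change is drawn from that pair.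

Compound 4 `CC(=O)OC[C@H]1O[C@H](OC[C@@H](Cn2cc(CN(c3nc(-c4ccc([N+](=O)[O-])cc4)no3)C3CCCCC3)nn2)OC(C)=O)C=C[C@@H]1OC(C)=O` differs from compound 2 in one place: 4-nitrophenyl in place of 3-methylphenyl on an aromatic carbon. Among the measured compounds shown here, no measured pair shows this same exchange, so its effect in this assay is unknown. Compound 4 is expected to show a step from compound 2 of a 1.2-fold lower number from compound 2 to compound 4 (0.09 log units; within the scatter), which is not expected to exceed the scatter, in a slightly lowering direction if any. Compound 4 is therefore estimated at 38 ug/mL, with a range from 18 ug/mL to 70 ug/mL.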

Compound 4, half-maximal cytotoxic concentration: 64.1 ug/mL
For compound 4 the middle estimate is 1.7-fold (0.23 log units) below the measured one, within the range that was stated.
By their numbers in this assay, from the lowest: compound 3; then compounds 1, 2 and 4 (each within the scatter of the next).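

In this assay, among the compounds shown here, the exchange of 3-methylphenyl for 4-nitrophenyl, on the aromatic carbon between two ring nitrogen atoms, gives a 1.4-fold higher number from compound 2 to compound 4 (0.14 log units; within the scatter) and is the first step that can be read at a single place. It shows that this position can carry either group with no separation beyond the scatter, so no order between the two is claimed. No measured evidence bears on this pair.

On these data alone, whether an amine, a carboxylic acid or a longer alkyl chain at this position would stay within the scatter remains open. As far as these compounds go, it also remains open how 4-bromophenyl, which appears here only in compound 3, would read on the core of compound 2.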